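The source may hold more compounds than are shown below. What is called first, only, known or untested is meant among the compounds shown, and "the series" means these compounds.

Compound 1 `COc1ccc(Cn2c(NCCNC(=N)N)nc(=O)n(Cc3ccc(C)cc3)c2=O)cc1` was tested in a functional assay on the whole organism (strain C57Bl/6) for inhibition, with Mus musculus as the target, with a stated time of 180 min, at 48 degrees C (a higher number here means that more compound is needed for the effect, a lower number that less compound is needed), where compound 1 gives 0.0044 nM. Among the three numbers obtained so far, compound 1 holds the second highest. Its nearest neighbour is compound 3 `Cc1ccc(Cn2c(=O)nc(NCCNC(=N)N)n(Cc3ccc(Cl)c(Cl)c3)c2=O)cc1`, which in this assay gives 0.0051 nM. That pair is the only one differing in a single place, and the step is small: a 1.2-fold higher number from compound 1 to compound 3 (0.06 log units; within the scatter), brought about by a 3,4-dichlorophenyl in place of the 4-methoxyphenyl on a saturated chain carbon bound to an aromatic nitrogen. Compound 2 `Cc1ccc(Cn2c(NCCNC(=N)N)nc(=O)n(Cc3ccc(C(F)(F)F)cc3)c2=O)cc1` gives 0.000033 nM in this assay, a number far below that of compound 1 and beyond the scatter; compound 2 differs from compound 1 in more than one place, so the two values show only that a large gap exists between them.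

Compound 4 `COc1ccc(Cn2c(NCCNC(=N)N)nc(=O)n(Cc3ccc([N+](=O)[O-])cc3)c2=O)cc1` has not yet been measured. It differs from compound 1 as follows: nitro in place of methyl on an aromatic carbon. Going by the values given here, no recorded step touches this position; the single measured step alters the other benzyl group and stays within the scatter. Compound 4 is therefore expected to sit near compound 1, the expected step being a 1.1-fold lower number from compound 1 to compound 4 (0.04 log units; within the scatter), nothing beyond the scatter. The estimate for compound 4 is 0.004 nM, with a range from 0.0012 nM to 0.013 nM.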

Compound 4, half-maximal effective concentration: 0.048 nM
The estimate for compound 4 lay 12-fold (1.08 log units) below the measured number; the whole stated range lies below it.
By their numbers in this assay, from the lowest: compound 2; then compounds 1 and 3 (each within the scatter of the next); then compound 4.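

The 4-methylbenzyl group of compound 1 proves not to be a freely exchangeable part of the structure: in this assay, going from 4-methylbenzyl to 4-nitrobenzyl gives an 11-fold higher number from compound 1 to compound 4 (1.04 log units; beyond the scatter), so more compound is needed for the effect. This is the first change shown at this aromatic carbon, and its size contrasts with the change on the other benzyl group, which gave a 1.2-fold higher number from compound 1 to compound 3 (0.06 log units; within the scatter) and stayed within the scatter. No measurement is available that explains why the nitro group has this effect.

Going by these compounds, with only methyl and nitro compared at this carbon on the core of compound 1, it remains open whether the higher number is specific to nitro or would also appear with another group there, such as an amine, a nitrile or a carboxylic acid. Also unresolved is whether nitro would produce a step of similar size on the 4-methoxybenzyl side of the molecule, or at another carbon of the same six-membered aromatic ring.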